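The source may report more compounds than this note shows. Statements on the series, on what has been measured and on what is new or still open speak of the compounds shown alone.

Series notes. Compound 3 `Cn1cncc1CN1CC(N(CC2CCN(C(=O)N3CCCC3)CC2)S(=O)(=O)c2ccccn2)Cc2cc(C#N)ccc21` gives 0.6 10^-6 cm/s in an ADME assay on Caco-2 cells (Homo sapiens) for permeability, in the apical to basolateral direction; on this read-out higher numbers stand for higher permeability and lower numbers for lower permeability. Compound 2 `Cn1cncc1CN1CC(N(CC2CCN(C(=O)N3CCCCC3)CC2)S(=O)(=O)c2ccccn2)Cc2cc(C#N)ccc21` gives 0.6 10^-6 cm/s in this assay, and compound 1 `C=C(C)C(=O)N1CCC(CN(C2Cc3cc(C#N)ccc3N(Cc3cncn3C)C2)S(=O)(=O)c2ccccn2)CC1` gives 0.5 10^-6 cm/s. The step of a 1.2-fold higher number from compound 1 to compound 3 (0.08 log units; within the scatter) and the step of no change at the digits printed from compound 2 to compound 3 (within the scatter) both lie within the scatter, so compound 3 is level with compound 2, the two together giving the highest of the three numbers, and compound 1 is the furthest away, the whole spread staying within the scatter.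

Compound 4 `Cn1cncc1CN1CC(N(CC2CCN(S(=O)(=O)c3ccccc3)CC2)S(=O)(=O)c2ccccn2)Cc2cc(C#N)ccc21` is the next compound. Structural change: phenylsulfonyl in place of (pyrrolidin-1-yl)carbonyl on an amine nitrogen in a ring. Among the measured steps, a 1.2-fold higher number from compound 1 to compound 2 (0.08 log units; within the scatter), a 1.2-fold higher number from compound 1 to compound 3 (0.08 log units; within the scatter) and no change at the digits printed from compound 2 to compound 3 (within the scatter) each alter only the group on the carbonyl carbon at the amine nitrogen in a ring, and none of them moved the number beyond the scatter. None replaces the carbonyl itself by a sulfonyl, so the change to compound 4 reaches past what the measured steps cover. On the evidence at hand, no step beyond the scatter is expected in this assay for compound 4, and the estimated step is no change at the digits printed from compound 3 to compound 4 (within the scatter). Compound 4 is therefore expected to give 0.6 10^-6 cm/s, with an expected range from 0.3 10^-6 cm/s to 1.3 10^-6 cm/s.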

Compound 4, apparent permeability: 0.1 10^-6 cm/s
Compound 4: middle estimate off by 6.0-fold (0.78 log units), on the high side; the whole stated range lies above it.
By their numbers in this assay, from the lowest: compound 4; then compounds 1, 2 and 3 (each within the scatter of the next).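

In this assay, among these compounds, the group on the amine nitrogen in a ring moves the number beyond the scatter for the first time: phenylsulfonyl gives a 6.0-fold lower number from compound 3 to compound 4 (0.78 log units; beyond the scatter) and a 6.0-fold lower number from compound 2 to compound 4 (0.78 log units; beyond the scatter) and also a 5.0-fold lower number from compound 1 to compound 4 (0.70 log units; beyond the scatter). The earlier steps shown here altered only the group on the carbonyl carbon and all stayed within the scatter, whereas this change replaces the carbonyl as well, and its three steps lie close together whichever carbonyl group leaves, so the read-out at this place tolerates changes on the carbonyl carbon but not this exchange of the whole group. No measurement at hand bears on why the number drops with this change.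

The sulfonyl and the phenyl ring enter together, so the compounds shown cannot tell which of the two goes with the lower number; a benzoyl or a methylsulfonyl group on the same nitrogen would separate them. Also open, as far as these compounds go, is how a benzyl group, with neither carbonyl nor sulfonyl on that nitrogen, would read in this assay.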